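A Fluoro for Methoxy Swap on the Pendant Phenyl

This account rests on a few compounds, and the source may have more. Where it says the series, first, only, none or still open, it means among the compounds named here.

Going by the values given here, compound 1 `CC(=O)Oc1ccc(-n2c(-c3ccccc3)cc3c2CCCC3)cc1C(=O)O` and compound 2 `COc1ccc(-c2cc3c(n2-c2ccc(O)c(C(=O)O)c2)CCCC3)cc1` share a core but differ in more than one place, so no single step between them can be read off. In a functional assay on the whole organism (strain Wistar) for inhibition, with Rattus norvegicus as the target, read by paw edema, with stated times of 30 min and 3 h, at a dose of 200 mg/kg by the oral route (a lower number here means less inhibition, a higher number more inhibition at the dose given (going by the name of the read-out)), compound 1 gives 50%. In this assay compound 2 gives 50%, level with compound 1 at the digits shown and within the scatter of it. Compound 3 `O=C(O)c1cc(-n2c(-c3ccc(F)cc3)cc3c2CCCC3)ccc1O` has not yet been measured in this assay. The change from compound 2 to compound 3 is fluoro in place of methoxy on an aromatic carbon. Among the compounds with values here, no measured pair in this set isolates this change, so the data give no direction for it. With the two measured compounds sitting at the same level, the expected step of no change at the digits printed from compound 2 to compound 3 (within the scatter) is none beyond the scatter. Compound 3 is therefore estimated at 50% in this assay, with a range from 35% to 65%.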

Compound 3, a percentage reported as inhibition, in the whole organism at one dose (the size of the read-out at that dose, not a potency): >= 60%
Compound 3: only a limit was reported (the forecaster's own chance of this, stated with the estimate: 0%); middle value at least 10 percentage points away from the limit.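

Going by these compounds alone, compound 2 and compound 3 form the only pair here that differs in one place, so this aromatic carbon gives the first step that can be read: in this assay, the change from methoxy to fluoro gives a number at least 10 percentage points higher from compound 2 to compound 3 (that floor lies within the scatter). For compound 3, the reported >= 60% is a limit of the assay and not a number. The floor of this step lies within the scatter, so the 4-methoxyphenyl to 4-fluorophenyl change is not shown to go beyond it, and the reading rests on a single limit: the limit of >= 60% in this assay, at which 1 of the 3 values shown sits.

The steps that involve compound 1 cannot be read, as it differs from the other two compounds in more than one place. The compounds shown leave open how a chloro group, an amine or a longer alkoxy chain on the same aromatic carbon would read out.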